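The source may report more compounds than this note shows. Statements on the series, on what has been measured and on what is new or still open speak of the compounds shown alone.

Measured so far:
- compound 1, `COc1ncc(-c2ccc3nc(NC4CC4)sc3c2)cc1NS(=O)(=O)c1ccc(F)cc1`: 1330 nM
- compound 2, `CCN(CC)CCNC(=O)Nc1nc2ccc(-c3cnc(OC)c(NS(=O)(=O)c4ccc(C)cc4)c3)cc2s1`: 310 nM
- compound 3, `CCN(CC)CCNC(=O)Nc1nc2ccc(-c3cnc(Cl)c(NS(=O)(=O)c4ccc(F)cc4)c3)cc2s1`: 5260 nM

These three compounds share a core and were all tested in a functional assay on A549 cells (Homo sapiens) for antiproliferative activity, read by MTT assay, with a stated time of 72 h; on this read-out lower numbers stand for stronger inhibition and higher numbers for weaker inhibition. Compound 1 gives 1330 nM, which stands second highest of the three numbers. Compound 3 gives 5260 nM, a higher number than compound 1 by more than the scatter; compound 2 gives 310 nM, a lower number than compound 1 by more than the scatter. No two of these compounds differ in only one place, so no single step can be read from them.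

Compound 4, `COc1ncc(-c2ccc3nc(NC(=O)NCCN4CCN(C)CC4)sc3c2)cc1NS(=O)(=O)c1ccc(F)cc1`, is not yet measured. It differs from compound 1 in one place: (2-(4-methylpiperazin-1-yl)ethyl)carbamoyl in place of cyclopropyl on a nitrogen on an aromatic ring. Compounds 2 and 3 both carry a carbamoyl bearing a chain with a basic nitrogen at this position, and their values in this assay fall on either side of compound 1, so the evidence for this kind of change is mixed. A moderate step is expected from compound 1 to compound 4, a 2.2-fold lower number from compound 1 to compound 4 (0.35 log units; beyond the scatter), toward a lower number, leaning on compound 2 with 310 nM. Compound 4 is thus estimated at 600 nM, within a range of 200 nM to 2000 nM.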

Compound 4, half-maximal inhibitory concentration: 550 nM
Compound 4: the middle estimate sits 1.1-fold (0.04 log units) above what was measured; the measured number falls inside the stated range.
By their numbers in this assay, from the lowest: compounds 2 and 4 (each within the scatter of the next); then compound 1; then compound 3.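

In this assay, among the compounds shown here, putting (2-(4-methylpiperazin-1-yl)ethyl)carbamoyl in place of cyclopropyl on a nitrogen on an aromatic ring gives a 2.4-fold lower number from compound 1 to compound 4 (0.38 log units; beyond the scatter), a modest step that is the first direct reading at this position. It shows that, with the rest of compound 1 unchanged, this position accepts a much larger group carrying a non-aromatic ring, and the number still falls rather than rises. No measurement shown here explains this step.

Compound 2 and compound 3 each differ from compound 4 in more than one place, so they cannot show how much the end of the chain matters. As far as these compounds go, it remains open whether a morpholine in place of the methylpiperazine, a longer chain, or a plain amine on this nitrogen would give a similar number.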